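Shortening the enone side chain in two aryl-thiazole series

The source may hold more compounds than are shown below. What is called first, only, known or untested is meant among the compounds shown, and "the series" means these compounds.

Compound 1 `C=C(CC)C(=O)c1ccc(OCc2nc(-c3ccc(C(F)(F)F)cc3)cs2)c(C)c1C` and compound 2 `C=C(C)C(=O)c1ccc(OCc2nc(-c3ccc(C(F)(F)F)cc3)cs2)c(C)c1C` share one core. In a functional assay on HL-60 cells (Homo sapiens) for inhibition, read by trypan blue exclusion, with a stated time of 72 h (a lower number here means a stronger inhibitor of growth, a higher number a weaker inhibitor of growth), compound 1 gives 1500 nM and compound 2 gives 3100 nM; the change between them, (hydrogen in place of methyl on a saturated chain carbon bound to a double-bonded chain carbon), brings a 2.1-fold higher number from compound 1 to compound 2 (0.32 log units; beyond the scatter). Compound 3 `C=C(CC)C(=O)c1ccc(OCc2nc(-c3ccc([N+](=O)[O-])cc3)cs2)cc1Cl` has a different core; how the two cores differ is not broken down here. In this assay compound 3 gives 800 nM, which is within the scatter of compound 1 and beyond it relative to compound 2. Compound 4 `C=C(C)C(=O)c1ccc(OCc2nc(-c3ccc([N+](=O)[O-])cc3)cs2)cc1Cl` has not yet been measured; it differs from compound 3 by hydrogen in place of methyl on a saturated chain carbon bound to a double-bonded chain carbon, the same change as that from compound 1 to compound 2, at the same place. Because that change gave a 2.1-fold higher number from compound 1 to compound 2 (0.32 log units; beyond the scatter), a comparable step a 2.0-fold higher number from compound 3 to compound 4 (0.30 log units; within the scatter) is expected here, so compound 4 is estimated at 1600 nM, between 800 nM and 3500 nM.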

Compound 4, concentration for 50% growth inhibition: 5900 nM
For compound 4 the middle estimate is 3.7-fold (0.57 log units) below the measured one, outside the stated range (above it).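

In this assay, the change from ethyl to methyl brings a 7.4-fold higher number from compound 3 to compound 4 (0.87 log units; beyond the scatter). The number rose on both cores, but the size of the step did not carry over from one core to the other: the same change on two cores in this assay, a 2.1-fold higher number (0.32 log units; beyond the scatter) from compound 1 to compound 2 and a 7.4-fold higher number (0.87 log units; beyond the scatter) from compound 3 to compound 4, 3.6-fold (0.55 log units) apart, beyond the scatter of two such steps With one pair on each core, this does not show which of the differences between the cores goes with the larger step, or how the step would behave on any third core.

Open, as far as these compounds go, is how a propyl chain at this place would compare with ethyl and methyl on either core. Also open, from the compounds shown here alone, is whether the step would change if only the nitro group, or only the chlorine, were exchanged.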